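A trimethoxyphenyl swap on a chloro analogue at the limit

The compounds below may be only part of what the source reports. "The series", "measured", "known", "first", "only" and "open" are said of these compounds alone.

Of the compounds shown here, three of one shared core have been measured. Compound 1 `Fc1ccc(C2CC(c3ccccc3)=NN2c2ccc(-c3ccccc3)nn2)cc1` gives 89200 nM in a functional assay on A549 cells (Homo sapiens) for antiproliferative activity, read by MTT assay, with a stated time of 24 h; a higher number here means a weaker inhibitor, a lower number a stronger inhibitor. Compound 2 `COc1ccc(C2CC(c3ccccc3)=NN2c2ccc(-c3ccccc3)nn2)c(OC)c1` gives 9560 nM in this assay. Within the data shown here, compound 3 `Fc1ccc(C2CC(c3ccc(Cl)cc3)=NN2c2ccc(-c3ccccc3)nn2)cc1` gives only the limit of > 100000 nM in this assay, so for compound 3 no number is known, only that its value is a limit (the limit of > 100000 nM in this assay, at which 1 of the 3 values shown sits).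

Two steps connect the measured compounds. From compound 1 to compound 2 the change of the aryl on the saturated ring carbon brought a 9.3-fold lower number from compound 1 to compound 2 (0.97 log units; beyond the scatter). From compound 1 to compound 3 the added chloro brought an at least 1.1-fold higher number from compound 1 to compound 3 (0.04 log units; that floor lies within the scatter).

Compound 4 `COc1cc(C2CC(c3ccc(Cl)cc3)=NN2c2ccc(-c3ccccc3)nn2)cc(OC)c1OC` is not yet measured. It differs from compound 3 in one place: 3,4,5-trimethoxyphenyl in place of 4-fluorophenyl on a saturated ring carbon. The step from compound 1 to compound 2 bears most directly on this change, since it too replaced 4-fluorophenyl with a methoxy-bearing phenyl on the saturated ring carbon, and it lowered the number by a modest amount beyond the scatter. The step from compound 1 to compound 3 shows that the chloro did not shift the number beyond the scatter. A lowering of similar size is therefore expected from compound 3 to compound 4, as an at least 5.0-fold lower number from compound 3 to compound 4 (0.69 log units; beyond the scatter). Compound 4 is expected to give about 20000 nM in this assay, estimated between 5000 nM and 100000 nM.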

Compound 4, half-maximal inhibitory concentration: 83300 nM
For compound 4 the middle estimate is 4.2-fold (0.62 log units) below the measured one, within the range that was stated.
By their numbers in this assay, from the lowest: compound 2; then compounds 4 and 1 (each within the scatter of the next). At a limit, above all of these: compound 3.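

In this assay, replacing the 4-fluorophenyl group on the saturated ring carbon with 3,4,5-trimethoxyphenyl, on a core that carries the 4-chlorophenyl group, gave an at least 1.2-fold lower number from compound 3 to compound 4 (0.07 log units; that floor lies within the scatter). The earlier change at this position, to 2,4-dimethoxyphenyl on a core without the chloro, gave a 9.3-fold lower number from compound 1 to compound 2 (0.97 log units; beyond the scatter), whereas the new result shows that a methoxy-bearing phenyl here does not always bring a lowering that can be read beyond the scatter. The true size of the new step stays unknown, because the value for compound 3 is only a limit: the limit of > 100000 nM in this assay, at which 1 of the 4 values shown sits.

It remains open whether the difference between the two steps follows from the number and placing of the methoxy groups or from the chloro on the other aryl ring, as the compounds shown do not separate the two. Also open, on these data alone, is how this position would respond to a phenyl group bearing an amine or a carboxylic acid, or to a longer chain in place of the aryl group.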